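The source may report more compounds than this note shows. Statements on the series, on what has been measured and on what is new or still open speak of the compounds shown alone.

Working notes on the sulfonyl series. Of the compounds shown here, three sharing one core have been measured in a functional assay on CHO.K1 cells for antagonist activity at prostaglandin D2 receptor 2 (Homo sapiens), read by GTPgammaS binding, with a stated time of 1 h; a higher number here means a weaker inhibitor, a lower number a stronger inhibitor. Compound 1 `CNC(=O)c1cccc(S(=O)(=O)c2ccccc2Cc2c3c(n(CC(=O)O)c2C)CCNC3=O)c1` gives 240 nM. Compound 2 `COc1ccc(S(=O)(=O)c2ccccc2Cc2c3c(n(CC(=O)O)c2C)CCNC3=O)cc1` gives 3.9 nM. Compound 3 `CCS(=O)(=O)c1ccccc1Cc1c2c(n(CC(=O)O)c1C)CCNC2=O` gives 550 nM, the highest number of the three; its nearest neighbour is compound 1, and the gap to compound 2 is the widest in the set, as a 140-fold higher number from compound 2 to compound 3 (2.15 log units; beyond the scatter) shows.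

Compound 4 `Cc1c(Cc2ccccc2S(=O)(=O)N2CCOCC2)c2c(n1CC(=O)O)CCNC2=O` has not yet been measured. It differs from compound 3 by morpholin-4-yl in place of ethyl on a sulfonyl sulfur. For the measured compounds named here, no measured step exchanges the ethyl for a non-aromatic ring, so the bearing steps are indirect. Replacing the ethyl by an aromatic group gave a 2.3-fold higher number from compound 1 to compound 3 (0.36 log units; beyond the scatter) read backwards and a 140-fold higher number from compound 2 to compound 3 (2.15 log units; beyond the scatter) read backwards, so the two aryl groups both gave lower numbers than the ethyl, by different amounts. A morpholin-4-yl is a ring but not an aromatic one, so a step in this assay of undetermined direction, probably modest, is expected. Compound 4 is estimated at 300 nM (range 70 nM to 1500 nM), which means an expected step of a 1.8-fold lower number from compound 3 to compound 4 (0.26 log units; within the scatter).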

Compound 4, half-maximal inhibitory concentration: 22 nM
Beside the measured number, compound 4's estimate is 14-fold (1.13 log units) above it, outside the stated range (below it).
By their numbers in this assay, from the lowest: compound 2; then compound 4; then compound 1; then compound 3.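

In this assay a non-aromatic ring on the sulfonyl sulfur can also give a low number: morpholin-4-yl in place of ethyl gives a 25-fold lower number from compound 3 to compound 4 (1.40 log units; beyond the scatter) and so an aryl group is not required. Aromatic versus non-aromatic does not by itself set the order: morpholin-4-yl in place of 3-(methylcarbamoyl)phenyl gives an 11-fold lower number from compound 1 to compound 4 (1.04 log units; beyond the scatter) while morpholin-4-yl in place of 4-methoxyphenyl gives a 5.6-fold higher number from compound 2 to compound 4 (0.75 log units; beyond the scatter) and the two aryl groups therefore fall on opposite sides of the morpholin-4-yl. Among these four compounds, 4-methoxyphenyl remains the group with the lowest number.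

From the compounds shown here alone, it remains open whether the ring oxygen of morpholin-4-yl matters, which a piperidin-1-yl ring, a piperazin-1-yl ring or an open-chain dimethylamino group on the same sulfur would test. Nothing available accounts for the size of these steps.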